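The source may hold more compounds than are shown below. What is called first, only, known or untested is meant among the compounds shown, and "the series" means these compounds.

Of the compounds shown here, three have been measured in a functional assay on DU-145 cells (Homo sapiens) for cytotoxicity, read by trypan blue exclusion, with a stated time of 96 h; on this read-out lower numbers stand for stronger inhibition and higher numbers for weaker inhibition: compound 1 `COC(=O)C(Nc1cc(CS(=O)(=O)/C=C/c2c(OC)cc(OC)cc2OC)ccc1OC)c1ccc(Br)cc1` gives 300 nM, compound 2 `COC(=O)C(Nc1cc(CS(=O)(=O)/C=C/c2c(OC)cc(OC)cc2OC)ccc1OC)c1ccc(OC)cc1` gives 250 nM, and compound 3 `COc1cc(OC)c(/C=C/S(=O)(=O)Cc2ccc(OC)c(NC(C(=O)O)c3ccc(Br)cc3)c2)c(OC)c1` gives 300 nM. Compound 4 `COc1ccc(C(Nc2cc(CS(=O)(=O)/C=C/c3c(OC)cc(OC)cc3OC)ccc2OC)C(=O)O)cc1` has not yet been measured.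

From compound 1 to compound 2 the change is methoxy in place of bromo on an aromatic carbon, and the step it made was a 1.2-fold lower number from compound 1 to compound 2 (0.08 log units; within the scatter). The core of compound 3 differs from the core of compound 1 by hydrogen in place of methyl on an oxygen next to a carbonyl group, which gave no change at the digits printed from compound 1 to compound 3 (within the scatter). Compound 4 differs from compound 3 by methoxy in place of bromo on an aromatic carbon: the same change, at the same place, now made on the core of compound 3. Because a 1.2-fold lower number from compound 1 to compound 2 (0.08 log units; within the scatter) stayed within the scatter, the matching step from compound 3 is expected to be a 1.2-fold lower number from compound 3 to compound 4 (0.08 log units; within the scatter), again within the scatter. Compound 4 is therefore estimated at 250 nM, with a likely range from 120 nM to 500 nM.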

Compound 4, half-maximal inhibitory concentration: 100 nM
The estimate for compound 4 lay 2.5-fold (0.40 log units) above the measured number; the measured number lies below the stated range.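

In this assay, methoxy in place of bromo on an aromatic carbon gave a 3.0-fold lower number from compound 3 to compound 4 (0.48 log units; beyond the scatter), hydrogen in place of methyl on an oxygen next to a carbonyl group gave a 2.5-fold lower number from compound 2 to compound 4 (0.40 log units; beyond the scatter), and the two changes taken together gave a 3.0-fold lower number from compound 1 to compound 4 (0.48 log units; beyond the scatter). The methoxy change cannot be told apart between the two cores, so these numbers fit its carrying over, though they do not prove that its size is the same: the same change on two cores in this assay, a 1.2-fold lower number (0.08 log units; within the scatter) from compound 1 to compound 2 and a 3.0-fold lower number (0.48 log units; beyond the scatter) from compound 3 to compound 4, 2.5-fold (0.40 log units) apart, within the scatter of two such steps. The hydrogen change reads the same way, and one pair of steps for each change neither establishes transfer across the series nor reveals a real dependence on the core: the same change on two cores in this assay, no change at the digits printed (within the scatter) from compound 1 to compound 3 and a 2.5-fold lower number (0.40 log units; beyond the scatter) from compound 2 to compound 4, 2.5-fold (0.40 log units) apart, within the scatter of two such steps.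

The compounds shown leave open how a chloro group or an amine at that aromatic carbon would behave. They also leave open what an amide would give in place of the ester or the carboxylic acid.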